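Ethyl in place of isopropyl on a shared trifluoromethyl core

This account rests on a few compounds, and the source may have more. Where it says the series, first, only, none or still open, it means among the compounds named here.

Measured so far:
- compound 1, `CCOC(=O)C1=C(C(F)(F)F)NC(=O)NC1c1ccsc1`: 3%
- compound 2, `CCOC(=O)C1=C(C(F)(F)F)NC(=O)NC1c1ccoc1`: 1%
- compound 3, `CC(C)OC(=O)C1=C(C(F)(F)F)NC(=O)NC1c1cccs1`: 7%

In an assay on HeLa cells for displacement of a labelled ligand from adenosine receptor A3 (Homo sapiens), read by radioligand binding, with a stated time of 180 min, tested at 1 uM (on this read-out lower numbers stand for less inhibition and higher numbers for more inhibition at the one concentration tested (going by the name of the read-out)), compound 3 gives 7%, the highest of the three numbers, yet its gap to compound 1 and to compound 2 lies within the scatter, so all three sit at about the same low level. Among the compounds with values here, the only measured step, a number 2 percentage points lower from compound 1 to compound 2 (within the scatter), concerns the aromatic ring on the saturated ring carbon and stays within the scatter.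

Compound 4, `CCOC(=O)C1=C(C(F)(F)F)NC(=O)NC1c1cccs1`, has not been measured. It differs from compound 3 by hydrogen in place of methyl on a saturated chain carbon bound to an oxygen next to a carbonyl group and a saturated chain carbon. Within the data shown here, no measured step touches this part of the molecule, so nothing shows what the ester change does on its own. Among the measured compounds shown here, the one step seen, between compound 1 and compound 2, was flat, and every compound so far is close to the floor of the read-out. A step of a number 3 percentage points lower from compound 3 to compound 4 (within the scatter) is therefore expected, none beyond the scatter. For compound 4 the estimate in this assay is 4%, between -5% and 13%.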

Compound 4, a percentage reported as inhibition, at one concentration (the size of the read-out at that concentration, not a potency): 1%
Compound 4: the middle estimate sits 3 percentage points above what was measured, and the stated range covers the measured number.
By their numbers in this assay, from the lowest: compounds 2, 4, 1 and 3 (each within the scatter of the next).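

In this assay, within the data shown here, the change from isopropyl to ethyl gives a number 6 percentage points lower from compound 3 to compound 4 (within the scatter) and offers the first direct look at this position on the ester, where the shorter chain leaves the reading within the scatter. With the ethyl ester held constant, thiophen-2-yl in place of furan-3-yl gives no change at the digits printed from compound 2 to compound 4 (within the scatter) and thiophen-2-yl in place of thiophen-3-yl gives a number 2 percentage points lower from compound 1 to compound 4 (within the scatter), so neither ring swap moves the number beyond the scatter. No independent measurement is available to explain these results.

As far as these compounds go, it remains open whether a longer chain such as butyl on the ester oxygen, or a carboxylic acid in place of the ester, would give a number beyond the scatter. The same question stands for an amine in place of trifluoromethyl on the shared core.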